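The source may report more compounds than this note shows. Statements on the series, on what has been measured and on what is new or still open speak of the compounds shown alone.

Going by the values given here, in a functional assay on HT-29 cells (Homo sapiens) for cytotoxicity, read by MTT assay, with a stated time of 72 h (a lower number here means a stronger inhibitor, a higher number a weaker inhibitor), compound 1 `Cc1c(C(=O)Nc2ccc(Oc3ccnc4[nH]ccc34)cc2)nnn1-c1ccc(F)cc1` gives 180 nM, the lowest of the two numbers measured so far. Compound 2 `Cc1c(C(=O)Nc2ccc(Oc3ccnc4[nH]ccc34)cc2)nnn1-c1ccc(F)c(F)c1` gives 1070 nM, and the step of a 5.9-fold higher number from compound 1 to compound 2 (0.77 log units; beyond the scatter) arose from a fluoro in place of hydrogen on an aromatic carbon. Compound 3 `O=C(Nc1ccc(Oc2ccnc3[nH]ccc23)cc1)c1nnn(-c2ccc(F)cc2)c1C(F)(F)F` differs from compound 1 by trifluoromethyl in place of methyl on an aromatic carbon. Among the compounds with values here, no measured step touches that place, so the only guide is that the single change seen so far moved the number modestly upward. The expectation for compound 3 is a step of a 1.8-fold higher number from compound 1 to compound 3 (0.25 log units; within the scatter), near the edge of the scatter. Compound 3 is therefore estimated at 320 nM, ranging from 80 nM to 1300 nM.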

Compound 3, half-maximal inhibitory concentration: 93 nM
Estimate against measurement, compound 3: 3.4-fold (0.54 log units) above, and the stated range covers the measured number.
By their numbers in this assay, from the lowest: compounds 3 and 1 (each within the scatter of the next); then compound 2.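

In this assay, going by these compounds alone, trifluoromethyl in place of methyl on this aromatic carbon gives a 1.9-fold lower number from compound 1 to compound 3 (0.29 log units; within the scatter), so the number holds through this exchange, unlike the one earlier change, at another place, which gave a 5.9-fold higher number from compound 1 to compound 2 (0.77 log units; beyond the scatter). This shows that the place on the five-membered ring can carry either group with no change beyond the scatter. Nothing measured here explains the result.

On these data alone, whether an ethyl group, an amine or a carboxylic acid at this place would also hold the number stays open. So does whether hydrogen alone would serve there.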